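Swapping the acetylpiperidinyl group for cyclopentyl on the imidazole nitrogen

The compounds below may be only part of what the source reports. "The series", "measured", "known", "first", "only" and "open" are said of these compounds alone.

Compound 3 `CC(=O)N1CCC(n2c(-c3ccc(OCc4c(-c5c(Cl)cccc5Cl)noc4C(C)C)cc3)nc3ccc(C(=O)O)cc32)CC1` is the weakest agonist of the three measured analogues: in an assay on Huh-7 cells for agonist activity at Bile acid receptor (Homo sapiens), read by a luciferase reporter (a higher number here means that more compound is needed for the effect, a lower number that less compound is needed), compound 3 gives 1430 nM, whereas compound 1 `CCn1c(-c2ccc(OCc3c(-c4c(Cl)cccc4Cl)noc3C(C)C)cc2)nc2ccc(C(=O)O)cc21` gives 2.31 nM and compound 2 `CC(C)c1onc(-c2c(Cl)cccc2Cl)c1COc1ccc(-c2nc3ccc(C(=O)O)cc3n2CC2CC2)cc1` gives 19.4 nM. The two steps that reach compound 3 are both large, a 620-fold higher number from compound 1 to compound 3 (2.79 log units; beyond the scatter) and a 74-fold higher number from compound 2 to compound 3 (1.87 log units; beyond the scatter), while the step between the two smaller substituents is modest, an 8.4-fold higher number from compound 1 to compound 2 (0.92 log units; beyond the scatter). Compound 4 `CC(C)c1onc(-c2c(Cl)cccc2Cl)c1COc1ccc(-c2nc3ccc(C(=O)O)cc3n2C2CCCC2)cc1` differs from compound 3 by cyclopentyl in place of 1-acetylpiperidin-4-yl on an aromatic nitrogen. The group that enters is a carbocyclic ring without the acceptor that the 1-acetylpiperidin-4-yl group carried, so the two large steps to compound 3 bear most directly on this change, and the modest step from compound 1 to compound 2 suggests that a bulkier hydrocarbon on this nitrogen costs some potency relative to ethyl. Compound 4 is therefore expected to show a 36-fold lower number from compound 3 to compound 4 (1.55 log units; beyond the scatter) in this assay, landing between compound 2 and compound 3. The estimate for compound 4 is 40 nM, with a range of 6 nM to 250 nM.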

Compound 4, half-maximal effective concentration: 13.6 nM
Compound 4: the middle estimate sits 2.9-fold (0.47 log units) above what was measured, within the range that was stated.
By their numbers in this assay, from the lowest: compound 1; then compounds 4 and 2 (each within the scatter of the next); then compound 3.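

In this assay, cyclopentyl in place of 1-acetylpiperidin-4-yl gives a 110-fold lower number from compound 3 to compound 4 (2.02 log units; beyond the scatter), while cyclopentyl and cyclopropylmethyl on this aromatic nitrogen cannot be told apart, with a 1.4-fold lower number from compound 2 to compound 4 (0.15 log units; within the scatter). Ethyl still differs from cyclopentyl, with a 5.9-fold higher number from compound 1 to compound 4 (0.77 log units; beyond the scatter), so a non-aromatic ring attached directly to this nitrogen does not by itself go with a value like that of compound 3, and the weak value tracks the 1-acetylpiperidin-4-yl group among these compounds. No evidence on the cause of these steps is at hand.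

The compounds shown leave open whether the loss belongs to the acetyl group or to the piperidine ring, which a free piperidin-4-yl and a cyclohexyl group on this nitrogen would help separate. They also leave open how a longer chain, such as n-propyl, would compare with ethyl here.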